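Adding a second chlorine to a benzyl group

This account rests on a few compounds, and the source may have more. Where it says the series, first, only, none or still open, it means among the compounds named here.

Four compounds share a core in which a benzyloxy amide hangs from a ring that also carries two phenyl groups. Compound 1 `O=C(NOCc1ccccc1)c1cn(-c2ccccc2)nc1-c1ccccc1` is the plain benzyloxy member. In a functional assay on A549 cells (Homo sapiens) for antiproliferative activity, read by MTT assay, with a stated time of 48 h, in the presence of a further agent that is not named here (a higher number here means a weaker inhibitor of growth, a lower number a stronger inhibitor of growth), compound 1 gives 5000 nM. Compound 2 `O=C(NOCc1ccccc1Cl)c1cn(-c2ccccc2)nc1-c1ccccc1` carries a chloro in place of hydrogen on an aromatic carbon, and in this assay compound 2 gives 10300 nM; the change chloro in place of hydrogen on an aromatic carbon makes a step of a 2.1-fold higher number from compound 1 to compound 2 (0.31 log units; beyond the scatter). Compound 3 `Cc1ccc(-c2nn(-c3ccccc3)cc2C(=O)NOCc2ccccc2Cl)cc1` differs from compound 2 by a methyl in place of hydrogen on an aromatic carbon, and in this assay compound 3 gives 380 nM, a step of a 27-fold lower number from compound 2 to compound 3 (1.43 log units; beyond the scatter). The difference between the cores of compound 1 and compound 3 is not broken down here.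

Compound 4 `Cc1ccc(-c2nn(-c3ccccc3)cc2C(=O)NOCc2ccc(Cl)cc2Cl)cc1` has not been measured. It differs from compound 3 by chloro in place of hydrogen on an aromatic carbon. This is the same kind of change as from compound 1 to compound 2, but not the same: there the chloro enters ortho to a large group, here it enters meta to a chloro group and para to a large group. For the measured compounds named here, because the only measured precedent, a 2.1-fold higher number from compound 1 to compound 2 (0.31 log units; beyond the scatter), was a modest weakening, the expected step for compound 4 is a 1.7-fold higher number from compound 3 to compound 4 (0.23 log units; within the scatter), with a wider spread owing to the different place. In this assay compound 4 is estimated at 650 nM, expected between 200 nM and 2500 nM.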

Compound 4, concentration for 50% growth inhibition: 1080 nM
Beside the measured number, compound 4's estimate is 1.7-fold (0.22 log units) below it, within the range that was stated.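

In this assay, the change from 2-chlorobenzyl to 2,4-dichlorobenzyl gives a 2.8-fold higher number from compound 3 to compound 4 (0.45 log units; beyond the scatter), so growth inhibition weakens when this chloro enters. Set beside the earlier chloro step, the new step points the same way on a second core, and the two sizes cannot be told apart: the same change on two cores in this assay, a 2.1-fold higher number (0.31 log units; beyond the scatter) from compound 1 to compound 2 and a 2.8-fold higher number (0.45 log units; beyond the scatter) from compound 3 to compound 4, 1.4-fold (0.14 log units) apart, within the scatter of two such steps. This shows that, in these two pairs, adding a chloro to the benzyl group carried a similar modest penalty even though the core differed and the chloro entered at a different place, but two pairs do not make a rule for the whole series and do not explain why the number rises.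

Going by these compounds, it remains open whether the same step would appear on a third core, and whether a chloro on the benzyl group of compound 3 would give a similar step at other places on that group. On these data alone, it is also open whether a different group at the place taken by the new chloro, such as a methoxy group, an amine or a carboxylic acid, would weaken growth inhibition as chloro does or shift the number the other way.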